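Swapping a methoxyphenyl for a nitrofuran on the amine

The compounds below may be only part of what the source reports. "The series", "measured", "known", "first", "only" and "open" are said of these compounds alone.

Compound 1 `CCc1nc2cc(Cl)ccn2c1C(=O)NCc1ccc2c(c1)CCN(Cc1ccc(OC)cc1)C2` was tested in an ADME assay on Vero cells (Chlorocebus sabaeus) for cytotoxicity, read by MTT assay, with a stated time of 72 h (a lower number here means that less compound is tolerated, a higher number that more compound is tolerated), where compound 1 gave 32 ug/mL. Among the compounds with values here, this is the only plain number available in this assay. Within the data shown here, a second compound, compound 2 `CCc1nc2ccc(Cl)cn2c1C(=O)NCc1ccc2c(c1)CCN(Cc1ccc(F)cc1)C2`, differs from compound 1 in more than one place, so no single step between them can be read. In this assay compound 2 gave > 64 ug/mL, which is a limit of the assay rather than a number, as noted in the limit of > 64 ug/mL in this assay, at which 1 of the 2 values shown sits.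

Compound 3 `CCc1nc2cc(Cl)ccn2c1C(=O)NCc1ccc2c(c1)CCN(Cc1ccc([N+](=O)[O-])o1)C2` has not yet been tested in this assay. It differs from compound 1 by 5-nitrofuran-2-yl in place of 4-methoxyphenyl on a saturated chain carbon bound to an amine nitrogen in a ring. Among the measured compounds shown here, with no measured step of this kind to lean on, the expectation for the step from compound 1 to compound 3 in this assay is a modest downward move, a 2.0-fold lower number from compound 1 to compound 3 (0.30 log units; within the scatter), somewhat beyond the usual scatter. The value expected for compound 3 in this assay is therefore 16 ug/mL, in a range from 6 ug/mL to 40 ug/mL.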

Compound 3, half-maximal cytotoxic concentration: > 64 ug/mL
Compound 3 was reported as a limit; the forecaster's own chance of this, stated with the estimate: 5%; middle value at least 4.0-fold (0.60 log units) away from the limit.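

In this assay, within the data shown here, the swap of 4-methoxyphenyl for 5-nitrofuran-2-yl on a saturated chain carbon bound to an amine nitrogen in a ring gives the first step that can be read at this position: an at least 2.0-fold higher number from compound 1 to compound 3 (0.30 log units; that floor lies within the scatter). From the compounds shown here alone, compound 3 is reported as > 64 ug/mL, which is a limit and not a number, so the step gives only a floor and the true size of the change stays unknown. The result also adds a second compound to those at the top of the range of this assay: the limit of > 64 ug/mL in this assay, at which 2 of the 3 values shown sit.

Going by these compounds, whether an amine or a carboxylic acid in place of the 5-nitrofuran-2-yl would also reach this limit remains open. Also open, on these data alone, is whether 5-nitrofuran-2-yl would give the same reading on the core of compound 2.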